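The source may hold more compounds than are shown below. What is called first, only, known or untested is meant among the compounds shown, and "the series" means these compounds.

In a functional assay on HepG2 cells (Homo sapiens) for cytotoxicity, read by MTT assay (a higher number here means a weaker inhibitor, a lower number a stronger inhibitor), three compounds on the shared core have been measured. Compound 1 `C=C1C(=O)[C@]23C[C@@]1(Cl)CC[C@H]2[C@@]12C=CC(=O)[C@](C)(C(=O)O1)[C@H]2[C@@H]3C(=O)OCc1ccccc1` gives 17900 nM, compound 2 `C=C1C(=O)[C@]23C[C@@]1(I)CC[C@H]2[C@@]12C=CC(=O)[C@](C)(C(=O)O1)[C@H]2[C@@H]3C(=O)OC` gives 87000 nM, and compound 3 `C=C1C(=O)[C@]23C[C@@]1(I)CC[C@H]2[C@@]12C=CC(=O)[C@](C)(C(=O)O1)[C@H]2[C@@H]3C(=O)OCc1ccccc1` gives 69500 nM. Compound 3 therefore lies within the scatter of compound 2 and stands at a clearly higher number than compound 1.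

Compound 4 `C=C1C(=O)[C@]23C[C@@]1(OC)CC[C@H]2[C@@]12C=CC(=O)[C@](C)(C(=O)O1)[C@H]2[C@@H]3C(=O)OCc1ccccc1` carries methoxy in place of iodo on a saturated ring carbon. The most relevant measured change is iodo in place of chloro on a saturated ring carbon, a 3.9-fold higher number from compound 1 to compound 3 (0.59 log units; beyond the scatter), a modest step beyond the scatter. For the measured compounds named here, it shows that this carbon's substituent can move the number, but no methoxy compound has been measured. The other measured change, phenyl in place of hydrogen, a 1.3-fold lower number from compound 2 to compound 3 (0.10 log units; within the scatter), stays within the scatter and says little about this exchange.

A modest move toward a lower number is expected in this assay, with the estimated step being a 2.3-fold lower number from compound 3 to compound 4 (0.36 log units; beyond the scatter). The estimate for compound 4 is 30000 nM, with an expected range of 10000 nM to 80000 nM.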

Compound 4, half-maximal inhibitory concentration: 35000 nM
Estimate against measurement, compound 4: 1.2-fold (0.07 log units) below, within the range that was stated.
By their numbers in this assay, from the lowest: compounds 1, 4, 3 and 2 (each within the scatter of the next, the first and the last beyond it).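

In this assay, compound 4 cannot be separated from either of its partners at this saturated ring carbon: methoxy in place of iodo gives (a 2.0-fold lower number from compound 3 to compound 4 (0.30 log units; within the scatter)) and methoxy in place of chloro gives (a 2.0-fold higher number from compound 1 to compound 4 (0.29 log units; within the scatter)). For the compounds shown here, the one step at this carbon beyond the scatter remains the exchange of the two halogens (a 3.9-fold higher number from compound 1 to compound 3 (0.59 log units; beyond the scatter)), so replacing a halogen with an oxygen-linked group does not open a larger gap in this small set. No measured data bear on the cause of these numbers.

As far as these compounds go, whether a hydroxyl, an amine or a longer alkoxy chain on this carbon would stay within the same band remains open. So does whether methoxy reads the same alongside the methyl ester of compound 2 instead of the benzyl ester.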